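The compounds below may be only part of what the source reports. "The series", "measured", "known", "first", "only" and "open" are said of these compounds alone.

Compound 1 `COc1ccc(-c2nc(/N=C(\N)N(C)C)sc2-c2ccc(OC)cc2)cc1` is the anchor of this small set. Among the compounds with values here, in a functional assay with Oryctolagus cuniculus as the target (a higher number here means a weaker inhibitor, a lower number a stronger inhibitor), compound 1 gives 37 nM, and it is the only compound in the set for which a number rather than a limit was reported. Compound 3 `CCN(CC)C(=O)c1nc(-c2ccc(OC)cc2)c(-c2ccc(OC)cc2)s1` gives < 10 nM in this assay, which is a limit of the assay and not a number (the limit of < 10 nM in this assay, at which 1 of the 3 values shown sits). Compound 2 `COc1ccc(-c2nc(/N=C(\N)NC3CCCCC3)sc2-c2ccc(OC)cc2)cc1` gives > 1000 nM in this assay, again a limit rather than a number (the limit of > 1000 nM in this assay, at which 1 of the 3 values shown sits). The measured steps are therefore bounds: an at least 3.7-fold lower number from compound 1 to compound 3 (0.56 log units; beyond the scatter), an at least 27-fold higher number from compound 1 to compound 2 (1.43 log units; beyond the scatter), and an at least 100-fold lower number from compound 2 to compound 3 (2.00 log units; beyond the scatter).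

Compound 4 `COc1ccc(-c2nc(/C=C/C(=O)O)sc2-c2ccc(OC)cc2)cc1` is not yet measured. It differs from compound 1 in one place: a group of 5 heavy atoms (3 carbon, 2 oxygen; no ring) in place of a group of 6 heavy atoms (3 carbon, 3 nitrogen; no ring), on an aromatic carbon. The step from compound 1 to compound 3 shows that this position tolerates a group quite unlike the one it replaces and still gives a lower number, while the step from compound 1 to compound 2 shows that not every alteration around this position is tolerated. Neither replacement resembles the 2-carboxyethenyl group closely, so the expectation is cautious. Compound 4 is expected to land near compound 1, at 60 nM with a range of 12 nM to 400 nM, so that the estimated step is a 1.6-fold higher number from compound 1 to compound 4 (0.21 log units; within the scatter), not clearly beyond the scatter.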

Compound 4, half-maximal inhibitory concentration: > 100 nM
Compound 4 gave a limit, no number; the forecaster's own chance of this, stated with the estimate: 15%; middle value at least 1.6-fold (0.22 log units) from the limit.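

The value of compound 4 in this assay is a limit of the assay and not a number: the limit of > 100 nM in this assay, at which 1 of the 4 values shown sits. Compound 3 had shown that a group quite unlike the original could sit on this aromatic carbon, whereas 2-carboxyethenyl, which carries the same counts of hydrogen-bond donors and acceptors as the group it replaces, gives an at least 2.7-fold higher number from compound 1 to compound 4 (0.43 log units; beyond the scatter). With an at least 10-fold higher number from compound 3 to compound 4 (1.00 log units; beyond the scatter), the two replacements of the whole group also separate clearly from each other, so the higher number seen earlier with cyclohexylamino is no longer confined to a change on the amino side of the original group.

As far as these compounds go, the steps involving compound 2 and compound 4 together cannot be read, since both values are limits, and the actual distance of compound 4 from the other compounds remains unknown. The compounds shown also leave open whether the carboxylic acid or the double bond of the chain matters more, which a saturated chain ending in a carboxylic acid, or a diethylamide in place of the acid on the same ethenyl chain, would help to separate.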